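Working notes: from compound 3 to compound 4

A few compounds are considered here, and "the series" means these few. Any claim that something is new, unique, unknown or untested is made for them only; others in the source may bear on it.

Results so far in an ADME assay on microsomes from liver (Homo sapiens) for metabolic stability, with a stated time of 0.5 h; a higher number here means that more of the compound is left, a lower number that less of the compound is left:
compound 1 `Cn1c(=O)c(S(C)(=O)=O)c(CCc2ccccc2)c2cc(OCC(=O)NCc3ccc(Cl)c(Cl)c3)ccc21` gives "not determined" (no result reported)
compound 2 `CS(=O)(=O)c1c(CCc2ccccc2)c2cc(OCC(=O)NCC3CC3)ccc2[nH]c1=O` gives "not determined" (no result reported)
compound 3 `CS(=O)(=O)c1c(CCc2ccccc2)c2cc(OCC(=O)Nc3ccccc3)ccc2[nH]c1=O` gives 67%

Going by the values given here, compound 3 holds the only number (67%), so it cannot be ranked. Among the compounds with values here, compound 1 and compound 2 offer no comparison, and no pair of measured compounds gives a step that could serve as a guide.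

The next compound to be measured is compound 4 `CN(Cc1ccc(Cl)c(Cl)c1)C(=O)COc1ccc2[nH]c(=O)c(S(C)(=O)=O)c(CCc3ccccc3)c2c1`. It carries (3,4-dichlorobenzyl)(methyl)amino in place of anilino on a carbonyl carbon. Within the data shown here, this exchange is not a small one by the counts, and the series holds no measured precedent for its size or direction in this assay.

Any expectation therefore rests on a single anchor, compound 3 at 67% in the same read-out, and the range has to stay wide. A fall somewhat beyond the usual scatter is the working expectation, though this is a judgement and not a trend seen in the data. The estimated change is a number 17 percentage points lower from compound 3 to compound 4 (beyond the scatter) and a result within the scatter would not be surprising.

Expected for compound 4 is 50% with a range of 25% to 75% as a working estimate.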

Compound 4, percent of the compound remaining: 0%
For compound 4 the middle estimate is 50 percentage points above the measured one; measured number below the stated range.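

In this assay, going by these compounds alone, (3,4-dichlorobenzyl)(methyl)amino in place of anilino on the carbonyl carbon gives a step of a number 67 percentage points lower from compound 3 to compound 4 (beyond the scatter), the first evidence that the group at this place can have a large effect on this read-out. The shared core and the rest of the side chain therefore do not by themselves hold the value seen for compound 3, since compound 4 keeps them and still gives 0%. The exchange also changes several things at once, with the amide hydrogen gone and a methyl, a benzyl link and two chlorines present, and nothing available bears on which of these lies behind the step.

Compounds 1 and 2 carry related amides but have no numbers, so steps involving them cannot be read, and the series does not show whether the methyl on the amide nitrogen, the benzyl link or the chlorines alone would give a step of this size. Also open, as far as these compounds go, is how a morpholine amide or a carboxylic acid at this carbonyl carbon would read in this assay.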